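Swapping the aryl on a hydrazone-linked adenosine analogue

The source may hold more compounds than are shown below. What is called first, only, known or untested is meant among the compounds shown, and "the series" means these compounds.

Measured so far:
compound 1, `Nc1nc(N/N=C/c2ccc(-c3ccc(Br)cc3)o2)nc2c1ncn2[C@@H]1O[C@H](CO)[C@@H](O)[C@H]1O`: 4.5 nM
compound 2, `COc1cc(/C=N/Nc2nc(N)c3ncn([C@@H]4O[C@H](CO)[C@@H](O)[C@H]4O)c3n2)ccc1OCc1ccccc1`: 9140 nM
compound 3, `Nc1nc(N/N=C/c2ccc3ncccc3c2)nc2c1ncn2[C@@H]1O[C@H](CO)[C@@H](O)[C@H]1O`: 9.8 nM

All three share one core and differ only in the aryl group carried on the carbon with a double bond to nitrogen. In an assay on CHO-K1 cells for displacement of a labelled ligand from adenosine receptor A1 (Homo sapiens), read by scintillation counting, with a stated time of 60 min (a higher number here means a weaker inhibitor, a lower number a stronger inhibitor), compound 3 gives 9.8 nM, the second highest of the three numbers. Its nearest neighbour is compound 1, whose number is lower by an amount beyond the usual scatter; compound 2 lies far away, with a number higher by an amount well beyond the usual scatter. Compound 4, `Nc1nc(N/N=C/c2ccc(Cl)c(C(F)(F)F)c2)nc2c1ncn2[C@@H]1O[C@H](CO)[C@@H](O)[C@H]1O`, has not yet been measured. It differs from compound 3 in one place: 4-chloro-3-(trifluoromethyl)phenyl in place of quinolin-6-yl on a carbon with a double bond to nitrogen. Among the measured compounds shown here, no pair of measured compounds shows exactly this kind of exchange, so the size of the step must be guessed. Both compound 1 and compound 3 show that an aromatic group here can give a low number, while compound 2 shows that a substituted phenyl can give a very high one. The expectation for compound 4 is a modest step upward, a 3.1-fold higher number from compound 3 to compound 4 (0.49 log units; beyond the scatter), beyond the scatter but far short of compound 2. The estimated value for compound 4 in this assay is 30 nM, within a range from 6 nM to 150 nM.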

Compound 4, inhibition constant: > 10000 nM
Compound 4 was reported as a limit (the forecaster's own chance of this, stated with the estimate: 2%); middle value at least 330-fold (2.52 log units) from the limit.
By their numbers in this assay, from the lowest: compound 1; then compound 3; then compound 2. At a limit, above all of these: compound 4.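

Exchanging quinolin-6-yl for 4-chloro-3-(trifluoromethyl)phenyl on the carbon with a double bond to nitrogen gives an at least 1000-fold higher number from compound 3 to compound 4 (3.00 log units; beyond the scatter) in this assay, so this position can separate two aromatic groups of nearly the same heavy-atom count very sharply. Compound 4 gives > 10000 nM, which is a limit of the assay and not a number. Compound 2 had already shown a substituted phenyl with a high number, and compound 4 now adds a second, much smaller one, so among the compounds shown, a high number here does not need a group as large as that of compound 2.

The change removes the second ring and the ring nitrogen and adds chlorine and trifluoromethyl all at once, so the compounds shown cannot tell which of these matters. Plain phenyl, or a phenyl carrying only chlorine or only trifluoromethyl, would begin to separate them.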